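The compounds below may be only part of what the source reports. "The series", "measured", "known", "first", "only" and "open" are said of these compounds alone.

Measured in a functional assay on PC-9 cells (Homo sapiens) for inhibition, read by MTT assay, with a stated time of 48 h, tested at 10 uM; a lower number here means less inhibition, a higher number more inhibition at the concentration tested (going by the name of the read-out):

compound 1 `Cc1ccc(Nc2cc(NC(=O)Nc3c(Cl)cccc3Cl)ncn2)cc1C` — 92.1%
compound 2 `COc1cc(NC(=O)Nc2cc(Nc3ccc(F)c(Cl)c3)ncn2)cc(OC)c1` — 77.5%
compound 3 `COc1cc(NC(=O)Nc2cc(Nc3cc(C(F)(F)F)ccc3OC)ncn2)cc(OC)c1` — 81.1%

Compound 1 gives the highest number of the three in this assay. Compound 3 comes nearest, its value lying below that of compound 1 by more than the usual scatter, and compound 2 lies furthest, also below by more than the scatter. For the measured compounds named here, none of the three measured compounds differs from another in a single place, so no step between measured compounds is available to calibrate the change considered here.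

The unmeasured compound 4 `O=C(Nc1cc(Nc2ccc(F)c(Cl)c2)ncn1)Nc1c(Cl)cccc1Cl` is reached from compound 1 by one change: 3-chloro-4-fluorophenyl in place of 3,4-dimethylphenyl on a nitrogen on an aromatic ring. Going by the values given here, the group entering is the one already present in compound 2 on the same nitrogen, though compound 2 carries a different group on the urea, so its value is only an indirect guide.

In this assay compound 4 is expected to give about 84%, in a range from 70% to 95%. The expected step of a number 8.1 percentage points lower from compound 1 to compound 4 (within the scatter) is a modest fall, close to the edge of the scatter. The downward lean is estimated because compound 2 with the same entering group gives 77.5% in this assay, while compound 1 remains the reference point for the shared urea.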

Compound 4, a percentage reported as inhibition, at one concentration (the size of the read-out at that concentration, not a potency): 91.1%
Beside the measured number, compound 4's estimate is 7.1 percentage points below it; the measured number falls inside the stated range.
By their numbers in this assay, from the lowest: compounds 2, 3, 4 and 1 (each within the scatter of the next, the first and the last beyond it).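

In this assay, for the compounds shown here, exchanging 3,4-dimethylphenyl for 3-chloro-4-fluorophenyl on a nitrogen on an aromatic ring gives a number 1 percentage points lower from compound 1 to compound 4 (within the scatter), the first single-place step, and at this concentration the two groups cannot be told apart with the urea group of compound 1 in place. With the same 3-chloro-4-fluorophenyl group, compound 4 gives 91.1% and compound 2, which carries a different group on the urea, gives 77.5%, so the entering group alone does not set the reading at the value of compound 2. No measurement available here accounts for the two aryl groups reading alike.

From the compounds shown here alone, both groups compared are substituted phenyl rings of equal heavy-atom size, so it remains open whether a non-aromatic group on that nitrogen, such as a morpholine-bearing ethyl chain or a phenyl ring carrying a carboxylic acid, would hold the reading. A single tested concentration also leaves open whether compound 1 and compound 4 would separate in a full concentration series.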